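Sulfanyl for sulfonyl on the fluoro-bearing core

This account rests on a few compounds, and the source may have more. Where it says the series, first, only, none or still open, it means among the compounds named here.

Compound 1 `CSc1ccc(C)cc1NCC1=NCCN1` and compound 2 `Cc1ccc(S(C)(=O)=O)c(NCC2=NCCN2)c1` share one core; compound 3 `CS(=O)(=O)c1cc(F)ccc1NCC1=NCCN1` has another. In a functional assay for agonist activity at Alpha-1A adrenergic receptor (Homo sapiens) (a higher number here means a larger maximal response, a lower number a smaller maximal response), compound 1 gives 101%, compound 2 gives 98%, and compound 3 gives 61%, the lowest of the three, both other values standing beyond the scatter above it. The step of a number 3 percentage points higher from compound 2 to compound 1 (within the scatter) comes from methylsulfanyl in place of methylsulfonyl on an aromatic carbon. How the cores of compound 3 and compound 2 differ is not broken down here. Compound 4 `CSc1cc(F)ccc1NCC1=NCCN1`, not yet measured in this assay, is reached from compound 3 by methylsulfanyl in place of methylsulfonyl on an aromatic carbon: the same kind of change as from compound 2 to compound 1, though there the place was para to a methyl group and here it is meta to a fluoro group. Because a number 3 percentage points higher from compound 2 to compound 1 (within the scatter) lay within the scatter, the step of a number 4 percentage points higher from compound 3 to compound 4 (within the scatter) is expected to be small as well. Compound 4 is therefore estimated at 65%, between 45% and 90%. The range is kept wide: the surroundings of the place differ between the two changes.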

Compound 4, largest response reached (reported as maximum), in percent of the reference or control that the assay uses: 93%
Estimate against measurement, compound 4: 28 percentage points below, outside the stated range (above it).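

In this assay, methylsulfanyl in place of methylsulfonyl on an aromatic carbon gives a number 32 percentage points higher from compound 3 to compound 4 (beyond the scatter), and the size of this step does not carry over from the other core: the same change on two cores in this assay, a number 3 percentage points higher (within the scatter) from compound 2 to compound 1 and a number 32 percentage points higher (beyond the scatter) from compound 3 to compound 4, 29 percentage points apart, beyond the scatter of two such steps

The size of the step therefore depends on the core for these two pairs, so a step read on one core is a poor guide to the other. Two pairs do not show which difference between the cores matters, nor how the change would behave on any third core.

The compounds shown leave open how a methoxy group or an ethylsulfanyl group would compare on the same aromatic carbon of either core. Also open, as far as these compounds go, is whether a chloro group in place of the fluoro group would keep the large step.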